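Changing the Group on the Sulfonyl Sulfur of Compound 3

This account rests on a few compounds, and the source may have more. Where it says the series, first, only, none or still open, it means among the compounds named here.

In a functional assay on A2780 cells (Homo sapiens) for cytotoxicity, read by sulforhodamine B assay, with a stated time of 72 h (on this read-out lower numbers stand for stronger inhibition and higher numbers for weaker inhibition), three compounds with a shared core have been measured. Compound 1 `O=C(NCc1ccc(S(=O)(=O)C2CCC(F)(F)CC2)cc1)N1Cc2ccncc2C1` gives 13 nM, compound 2 `O=C(NCc1ccc(S(=O)(=O)N2CCC(O)CC2)cc1)N1Cc2ccncc2C1` gives 98 nM, and compound 3 `CN1CCN(S(=O)(=O)c2ccc(CNC(=O)N3Cc4ccncc4C3)cc2)CC1` gives 71 nM. Compound 3 therefore holds the second highest of the three numbers, within the scatter of compound 2 and clearly higher than compound 1.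

The next compound, compound 4 `O=C(NCc1ccc(S(=O)(=O)N2CCC(N3CCCC3)CC2)cc1)N1Cc2ccncc2C1`, keeps the rest of compound 3 and changes one group on a sulfonyl sulfur. It carries 4-(pyrrolidin-1-yl)piperidin-1-yl in place of 4-methylpiperazin-1-yl (4-(pyrrolidin-1-yl)piperidin-1-yl in place of 4-methylpiperazin-1-yl on a sulfonyl sulfur).

All three measured steps involve this same place. One swap gave a 1.4-fold lower number from compound 2 to compound 3 (0.14 log units; within the scatter), which stays within the scatter. The two others gave a 7.5-fold higher number from compound 1 to compound 2 (0.88 log units; beyond the scatter) and a 5.5-fold higher number from compound 1 to compound 3 (0.74 log units; beyond the scatter), both modest but beyond the scatter. Going by the values given here, no measured compound carries the entering group, so these steps offer only a rough guide to how far the number may move. They suggest that a change here can matter, but not by a large amount.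

The expected result is a 1.2-fold lower number from compound 3 to compound 4 (0.07 log units; within the scatter), which would be no step beyond the scatter in this assay. For compound 4 the estimate is 60 nM, with an expected range from 20 nM to 180 nM.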

Compound 4, half-maximal inhibitory concentration: 5.6 nM
Estimate against measurement, compound 4: 11-fold (1.03 log units) above; measured number below the stated range.
By their numbers in this assay, from the lowest: compound 4; then compound 1; then compounds 3 and 2 (each within the scatter of the next).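

In this assay, the earlier swaps on the sulfonyl sulfur gave modest steps at most, yet a 13-fold lower number from compound 3 to compound 4 (1.10 log units; beyond the scatter) shows that this position can move the number much further than those compounds suggested. The comparison with the hydroxy compound points the same way, since an 18-fold lower number from compound 2 to compound 4 (1.24 log units; beyond the scatter) comes from placing pyrrolidin-1-yl in place of hydroxy on a saturated ring carbon, while a 2.3-fold lower number from compound 1 to compound 4 (0.37 log units; beyond the scatter) shows that 4,4-difluorocyclohexyl is not needed for the lowest number in this set, although compounds 2 and 3 had both given higher numbers than compound 1. Nothing available here explains why the entering group has this effect.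

The compounds shown leave open whether the gain depends on the pyrrolidine ring itself or would also appear with another amine on the same saturated ring carbon, such as dimethylamino or piperidin-1-yl. A simple piperidin-1-yl group on the sulfonyl sulfur, with no substituent on its ring, would also help to show how much of the step depends on having any group on that ring carbon.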